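The source may hold more compounds than are shown below. What is called first, only, known or untested is meant among the compounds shown, and "the series" means these compounds.

Measured in an in vitro functional assay on 1321-N1 cells for agonist activity at Free fatty acid receptor 1 (Homo sapiens), read by fluorescence, spectrophotometry and calcium flux; on this read-out higher numbers stand for larger maximal responses and lower numbers for smaller maximal responses:
compound 1 `Cc1ccccc1-c1cc(C#Cc2ccc(CCC(=O)O)cc2)ccn1` — compound 1 gives 92%
compound 2 `O=C(O)CCc1ccc(C#Cc2ccnc(-c3ccccc3)c2)cc1` — compound 2 gives 97%
compound 3 `O=C(O)CCc1ccc(C#Cc2cccs2)cc1` — compound 3 gives 97%

Compound 3 stands level with compound 2 at the digits given, the two together the highest of the three numbers, and it lies nearest to compound 2 with no change; compound 1 sits lowest, though its distance to compound 3 is within the scatter. For the measured compounds named here, the only single-point step measured, a number 5 percentage points higher from compound 1 to compound 2 (within the scatter), concerns hydrogen in place of methyl on an aromatic carbon and lies within the scatter.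

Compound 4 `O=C(O)CCc1ccc(C#Cc2ccccn2)cc1` is not yet measured. It differs from compound 3 by pyridin-2-yl in place of thiophen-2-yl on a triple-bonded carbon. Going by the values given here, no measured step changes the group on the triple-bonded carbon, so the one step known bears only loosely on it; what can be read is that compound 2 and compound 3, which carry different groups at that position, show the same number. No step beyond the scatter is therefore expected in this assay for compound 4, with a number 4 percentage points lower from compound 3 to compound 4 (within the scatter) as the estimated step. Compound 4 is expected to give 93%, within 75% to 102%.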

Compound 4, largest response reached (reported as efficacy), in percent of the reference or control that the assay uses: 98%
Beside the measured number, compound 4's estimate is 5 percentage points below it; low and high end bracket the measured number.
By their numbers in this assay, from the lowest: compounds 1, 2, 3 and 4 (each within the scatter of the next).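

In this assay, pyridin-2-yl in place of thiophen-2-yl on a triple-bonded carbon gives a number 1 percentage points higher from compound 3 to compound 4 (within the scatter), the first step measured directly at this position. For this one pair, a six-membered aromatic ring and a five-membered aromatic ring, each with 1 hetero atom, therefore cannot be told apart by maximal response.

Every group on the triple-bonded carbon shown so far is an aromatic ring, so the response with a saturated ring such as cyclohexyl, a straight alkyl chain or an amine at this place remains open. Maximal response also leaves open whether compound 3 and compound 4 differ in the concentration needed to reach it. No evidence at hand bears on this result.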